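A few compounds are considered here, and "the series" means these few. Any claim that something is new, unique, unknown or untested is made for them only; others in the source may bear on it.

Measured in a functional assay on A20 cells (Mus musculus) for inhibition, with stated times of 1 h, 16 h and 24 h (on this read-out lower numbers stand for stronger inhibition and higher numbers for weaker inhibition), the three compounds on hand share a core and differ in the group on a carbonyl carbon:

- compound 1 `N#CC1(NC(=O)[C@@H]2C[C@@H](S(=O)(=O)c3ccccc3)C[C@H]2C(=O)N2CC3(COC3)C2)CC1` gives 248 nM
- compound 2 `CN1CCN(C(=O)[C@@H]2C[C@H](S(=O)(=O)c3ccccc3)C[C@H]2C(=O)NC2(C#N)CC2)CC1` gives 17 nM
- compound 3 `N#CC1(NC(=O)[C@@H]2C[C@@H](S(=O)(=O)c3ccccc3)C[C@H]2C(=O)N2CCC2)CC1` gives 44 nM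

Compound 3 has the middle number of the three. On one side lies a 2.6-fold higher number from compound 2 to compound 3 (0.41 log units; beyond the scatter), and on the other 5.6-fold lower number from compound 1 to compound 3 (0.75 log units; beyond the scatter).

The next compound, compound 4 `N#CC1(NC(=O)[C@@H]2C[C@@H](S(=O)(=O)c3ccccc3)C[C@H]2C(=O)N2CC(O)C2)CC1`, changes one spot of compound 3: hydroxy in place of hydrogen on a saturated ring carbon. Put simply, this is hydroxy in place of hydrogen on a saturated ring carbon.

Among the compounds with values here, no measured step makes exactly this change. The closest guide is a 5.6-fold lower number from compound 1 to compound 3 (0.75 log units; beyond the scatter), which shows that the plain azetidin-1-yl group goes with a stronger reading than the larger oxygen-bearing group of compound 1. Against any simple rule about size, a 15-fold lower number from compound 1 to compound 2 (1.16 log units; beyond the scatter) shows that a group of equal heavy-atom count can read far stronger.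

Hydroxy is a much smaller addition than the group in compound 1, so a modest rise is expected, and a step within the scatter would be no surprise. The expected step is a 1.6-fold higher number from compound 3 to compound 4 (0.20 log units; within the scatter). For compound 4 the estimated value is 70 nM, with an expected range from 25 nM to 190 nM.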

Compound 4, half-maximal inhibitory concentration: 572 nM
Compound 4: the middle estimate sits 8.2-fold (0.91 log units) below what was measured; the measured number lies above the stated range.
By their numbers in this assay, from the lowest: compound 2; then compound 3; then compound 1; then compound 4.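

In this assay, within the data shown here, this ring carbon proves far less tolerant than the earlier compounds suggested: hydroxy, a single heavy atom placed two ring bonds from the ring nitrogen, gives a 13-fold higher number from compound 3 to compound 4 (1.11 log units; beyond the scatter) and so moves the reading by a large step. Among these compounds, the 3-hydroxyazetidin-1-yl group also reads weaker than the two other groups, with a 34-fold higher number from compound 2 to compound 4 (1.53 log units; beyond the scatter) and a 2.3-fold higher number from compound 1 to compound 4 (0.36 log units; beyond the scatter) making compound 4 the weakest of the four, even though its group is smaller than the one in compound 1, so heavy-atom count alone does not order these groups. Nothing available here accounts for this sharp loss.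

Going by these compounds, it remains open whether the loss belongs to hydroxy itself or to any substituent on this carbon, a question that a methoxy group, a fluorine atom or an amine at the same place could help settle. On these data alone, it is also open whether a hydroxymethyl group, which sets the oxygen one carbon further out, would give a reading closer to that of compound 3 or to that of compound 4.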